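Replacing 2-carboxypiperidin-1-yl with (2-hydroxyethyl)amino

This account rests on a few compounds, and the source may have more. Where it says the series, first, only, none or still open, it means among the compounds named here.

Compound 1 `COc1ccc(/C=C\c2cc(OC)c(OC)c(OC)c2)cc1OCc1ccc(C=O)cc1` gives 900 nM
Compound 2 `COc1ccc(/C=C\c2cc(OC)c(OC)c(OC)c2)cc1OCc1ccc(CN2CCCC[C@H]2C(=O)O)cc1` gives > 10000 nM (a limit)
Compound 3 `COc1ccc(/C=C\c2cc(OC)c(OC)c(OC)c2)cc1OCc1ccc(CN2CCCC[C@@H]2C(=O)O)cc1` gives > 10000 nM (a limit)

In a functional assay on MC-38 cells (Mus musculus) for antiproliferative activity, read by CCK-8 assay, with a stated time of 48 h (on this read-out higher numbers stand for weaker inhibition and lower numbers for stronger inhibition), compound 3 sits at > 10000 nM as a limit of the assay, not a number. Compound 4 `COc1ccc(/C=C\c2cc(OC)c(OC)c(OC)c2)cc1OCc1ccc(CNCCO)cc1` carries (2-hydroxyethyl)amino in place of 2-carboxypiperidin-1-yl on a saturated chain carbon bound to an aromatic carbon. For the measured compounds named here, two measured steps bear on this change: an at least 11-fold higher number from compound 1 to compound 2 (1.04 log units; beyond the scatter) and an at least 11-fold higher number from compound 1 to compound 3 (1.04 log units; beyond the scatter) are both large and beyond the scatter, and each brought in (2-carboxypiperidin-1-yl)methyl in place of formyl. The third step is a step that the two limits leave unreadable from compound 2 to compound 3 and offers no size to work with. Compound 4 no longer carries that group, so in this assay a lower number, meaning stronger inhibition, is expected, moving back towards compound 1 at 900 nM without necessarily reaching it. The estimated change is an at least 4.0-fold lower number from compound 3 to compound 4 (0.60 log units; beyond the scatter) and it starts from a limit, which leaves its size uncertain. For compound 4 the estimate is 2500 nM with an expected range from 500 nM to 9000 nM in this assay.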

Compound 4, half-maximal inhibitory concentration: 1200 nM
Compound 4: the middle estimate sits 2.1-fold (0.32 log units) above what was measured, within the range that was stated.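

In this assay, the saturated chain carbon bound to an aromatic carbon can carry a nitrogen substituent without the loss seen with 2-carboxypiperidin-1-yl: placing (2-hydroxyethyl)amino there instead gives an at least 8.3-fold lower number from compound 3 to compound 4 (0.92 log units; beyond the scatter) and an at least 8.3-fold lower number from compound 2 to compound 4 (0.92 log units; beyond the scatter). Both of these steps start from a limit of the assay, not a number. Set against the formyl compound, ((2-hydroxyethyl)amino)methyl in place of formyl gives a 1.3-fold higher number from compound 1 to compound 4 (0.12 log units; within the scatter), so the two groups cannot be told apart here.

On these data alone, the change swaps the ring and the carboxylic acid at once, so which of them goes with the loss stays open; a plain piperidin-1-yl group would separate the two. As far as these compounds go, compound 2 and compound 3 both sit at limits, so the step between them cannot be read and the role of configuration also stays open.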